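A few compounds are considered here, and "the series" means these few. Any claim that something is new, unique, unknown or untested is made for them only; others in the source may bear on it.

In a functional assay on the whole organism (strain albino) with Mus musculus as the target, at a dose of 100 mg/kg by the intraperitoneal route (a higher number here means more inhibition at the dose given (going by the name of the read-out), a lower number less inhibition), compound 1 `O=C(Nc1ccc(I)cc1)Nn1c(-c2ccccc2)nc2ccccc2c1=O` gives 60%. For the measured compounds named here, compound 2 `O=C(Nc1ccc([N+](=O)[O-])cc1)Nn1c(-c2ccccc2)nc2ccccc2c1=O` gives 42% in this assay, the lower of the two numbers known, with compound 1 standing higher by a step beyond the scatter. Going by the values given here, the only measured step, a number 18 percentage points lower from compound 1 to compound 2 (beyond the scatter), arose from putting nitro in place of iodo. Compound 3 `O=C(Nc1ccc(F)cc1)Nn1c(-c2ccccc2)nc2ccccc2c1=O` differs from compound 2 by fluoro in place of nitro on an aromatic carbon. Among the compounds with values here, this removes the nitro whose arrival lowered the number from compound 1 to compound 2, and returns a halogen, though fluoro rather than iodo, so the one step that bears on it points upward, and a rise of similar size, or somewhat smaller, is expected in this assay. The estimate for compound 3 in this assay is therefore 54%, with a range from 38% to 70%, a step of a number 12 percentage points higher from compound 2 to compound 3 (beyond the scatter) that is expected to carry compound 3 back toward the number of compound 1.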

Compound 3, a percentage reported as inhibition, in the whole organism at one dose (the size of the read-out at that dose, not a potency): 54%
Compound 3: middle estimate and measured number agree at the digits printed; the measured number falls inside the stated range.
By their numbers in this assay, from the lowest: compound 2; then compounds 3 and 1 (each within the scatter of the next).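

In this assay, fluoro in place of nitro gives a number 12 percentage points higher from compound 2 to compound 3 (beyond the scatter), showing that the lower number of compound 2 is not shared by every replacement of iodo at this position. The second comparison, a number 6 percentage points lower from compound 1 to compound 3 (within the scatter), shows that fluoro and iodo cannot be told apart here, so among these three compounds only the nitro compound stands apart. No measurement at hand says why nitro differs from the two halogens.

From the compounds shown here alone, it remains open whether chloro or bromo would fall with fluoro and iodo, and whether an amine or a methoxy group at this place would sit with the halogens or with nitro. Also open, going by these compounds, is whether nitro would still stand apart at another dose.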